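The source may hold more compounds than are shown below. What is called first, only, known or untested is meant among the compounds shown, and "the series" means these compounds.

In a functional assay on PC-12 cells (Rattus norvegicus) for cytotoxicity, read by MTT assay, with stated times of 2 h and 24 h, tested at 1 uM (on this read-out lower numbers stand for a weaker effect and higher numbers for a stronger effect at the one concentration tested), compound 3 `Oc1cc(C(F)(F)F)ccc1-c1nc(-c2ccccc2O)n(-c2ccc(Br)cc2)n1` gives 69.4%, the top of the three numbers, yet all three sit within the scatter of one another: compound 2 `Oc1cc(C(F)(F)F)ccc1-c1nc(-c2ccccc2O)n(-c2ccc(Cl)cc2)n1` gives 68% and compound 1 `Oc1cc(C(F)(F)F)ccc1-c1nc(-c2ccccc2O)n(-c2ccc(F)cc2)n1` gives 67.2%. Compound 4 `Oc1cc(C(F)(F)F)ccc1-c1nc(-c2ccccc2O)n(-c2ccc(OC(F)(F)F)cc2)n1` differs from compound 3 by trifluoromethoxy in place of bromo on an aromatic carbon. The measured steps that bear on this change each swap one group for another at the same place: a number 0.8 percentage points higher from compound 1 to compound 2 (within the scatter), a number 2.2 percentage points higher from compound 1 to compound 3 (within the scatter) and a number 1.4 percentage points higher from compound 2 to compound 3 (within the scatter), none of them beyond the scatter. No replacement at this place has yet moved this assay. Compound 4 is expected to follow the same course, with an expected step of a number 1.4 percentage points lower from compound 3 to compound 4 (within the scatter) and an estimated value of 68%, ranging from 58% to 78%.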

Compound 4, a percentage reported as activity, at one concentration (the size of the read-out at that concentration, not a potency): 65.5%
The estimate for compound 4 lay 2.5 percentage points above the measured number; measured number inside the range.
By their numbers in this assay, from the lowest: compounds 4, 1, 2 and 3 (each within the scatter of the next).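

Trifluoromethoxy brings five heavy atoms and a hydrogen-bond acceptor where bromo has one heavy atom and no acceptor, yet in this assay the result is a number 3.9 percentage points lower from compound 3 to compound 4 (within the scatter) and a number 2.5 percentage points lower from compound 2 to compound 4 (within the scatter) and a number 1.7 percentage points lower from compound 1 to compound 4 (within the scatter) with no step beyond the scatter. The insensitivity at this place on the aromatic ring therefore extends beyond the three halogens to a larger group joined through oxygen.

As far as these compounds go, whether an amine or a carboxylic acid at this place, or any change elsewhere on the shared core, would shift this read-out remains open. Nothing available explains why these four compounds read alike.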